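This account rests on a few compounds, and the source may have more. Where it says the series, first, only, none or still open, it means among the compounds named here.

Compound 1 `O=C(c1ccccc1)c1cc(Cl)ccc1OCCn1ccc(=O)[nH]c1=O`: > 337000 nM
Compound 2 `O=C(c1cc(Cl)cc(Cl)c1)c1cc(Cl)ccc1OCCn1ccc(=O)[nH]c1=O`: > 284000 nM

In an ADME assay on MT4 cells (Homo sapiens) for cytotoxicity, read by MTT assay, with a stated time of 4 days (a lower number here means that less compound is tolerated, a higher number that more compound is tolerated), the reading for compound 2 is only a limit, > 284000 nM. The reading for compound 1 is also a limit, > 337000 nM.

Compound 3 `O=C(c1cc(F)cc(F)c1)c1cc(Cl)ccc1OCCn1ccc(=O)[nH]c1=O` differs from compound 2 in a single group: 3,5-difluorophenyl in place of 3,5-dichlorophenyl on a carbonyl carbon. Among the compounds with values here, the only measured step that bears on this change is a step that the two limits leave unreadable from compound 1 to compound 2, so it offers no size to carry over. In this assay, no step beyond the usual scatter is therefore expected, in either direction. The expected change is a step that the limit leaves unreadable from compound 2 to compound 3. The estimate for compound 3 is 307000 nM, with an expected range of 150000 nM to 450000 nM.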

Compound 3, half-maximal cytotoxic concentration in the MT4 assay: > 307000 nM
Compound 3: no number, only a limit (the forecaster's own chance of this, stated with the estimate: 85%); the middle value lies on the limit itself.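

Compound 3 gives only a limit in the MT4 assay, > 307000 nM. Within the data shown here, compound 1 and compound 2 also give only limits there, so no step to compound 3 can be read. The compounds shown leave open at what concentration any of the three reaches half-maximal cytotoxicity. In a physicochemical assay for solubility (on this read-out higher numbers stand for higher solubility and lower numbers for lower solubility), compound 2 gives 1900 nM and compound 3 gives 7300 nM, which is a 3.8-fold higher number from compound 2 to compound 3 (0.58 log units; beyond the scatter).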